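The compounds below may be only part of what the source reports. "The series", "measured", "known", "first", "only" and "open" are said of these compounds alone.

Series notes. The shared core carries a six-membered non-aromatic ring of carbon only; compound 1 `CS(=O)(=O)NC1CCC(CN2CCN(c3cc(=O)c4cc(C(F)(F)F)cc([N+](=O)[O-])c4s3)CC2)CC1` bears methanesulfonamido on a saturated ring carbon of that ring. Among the compounds with values here, in an ADME assay on Vero cells (Chlorocebus sabaeus) for cytotoxicity, read by MTT assay, with a stated time of 48 h (on this read-out lower numbers stand for stronger inhibition and higher numbers for weaker inhibition), compound 1 gives 48.5 ug/mL, the only plain number in this set. Compound 2 `Cc1ccc(C(=O)OC2CCC(CN3CCN(c4cc(=O)c5cc(C(F)(F)F)cc([N+](=O)[O-])c5s4)CC3)CC2)cc1` in this assay gives > 64 ug/mL, which is a limit of the assay. Compound 3 `COc1cccc(C(=O)OC2CCC(CN3CCN(c4cc(=O)c5cc(C(F)(F)F)cc([N+](=O)[O-])c5s4)CC3)CC2)c1` in this assay gives > 64 ug/mL, also a limit. The step of an at least 1.3-fold higher number from compound 1 to compound 2 (0.12 log units; that floor lies within the scatter) and the step of an at least 1.3-fold higher number from compound 1 to compound 3 (0.12 log units; that floor lies within the scatter) both end at the limit of > 64 ug/mL in this assay, at which 2 of the 3 values shown sit, so their true size is not readable; between them lies a step that the two limits leave unreadable from compound 2 to compound 3. Compound 4 `O=C(OC1CCC(CN2CCN(c3cc(=O)c4cc(C(F)(F)F)cc([N+](=O)[O-])c4s3)CC2)CC1)C1CCCCC1` is not yet measured; it differs from compound 1 by (cyclohexylcarbonyl)oxy in place of methanesulfonamido on a saturated ring carbon. The two measured steps from compound 1 point the same way and stop at the limit. For compound 4 the number is therefore expected at or beyond that limit, with a 1.4-fold higher number from compound 1 to compound 4 (0.16 log units; within the scatter) as the estimated step. Compound 4 is estimated at 70 ug/mL, within 40 ug/mL to 130 ug/mL, in this assay.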

Compound 4, half-maximal inhibitory concentration: > 64 ug/mL
Compound 4: no number, only a limit; the forecaster's own chance of this, stated with the estimate: 70%; the middle value lies beyond the limit too.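

In this assay compound 4 gives > 64 ug/mL, which is a limit of the assay and not a number. With (cyclohexylcarbonyl)oxy on the saturated ring carbon, the series now shows that an aromatic ring on the carbonyl carbon is not required for an ester to reach this limit, as the cyclohexyl ester of compound 4 does so too. The step is an at least 1.3-fold higher number from compound 1 to compound 4 (0.12 log units; that floor lies within the scatter), its true size is unknown, and the steps among the three esters cannot be read: the limit of > 64 ug/mL in this assay, at which 3 of the 4 values shown sit.

Any real differences among compound 2, compound 3 and compound 4 remain hidden at this limit. Also open, going by these compounds, is whether a free hydroxyl, an amine, a carboxylic acid or a cyclohexylcarbonyl amide at this position would stay at the limit or give a readable number.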